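A few compounds are considered here, and "the series" means these few. Any claim that something is new, unique, unknown or untested is made for them only; others in the source may bear on it.

Compounds 1, 2 and 3 share one core and differ only in the group on a saturated ring carbon of the six-membered non-aromatic ring. In an assay on CHO cells for displacement of a labelled ligand from 5-hydroxytryptamine receptor 1D (Homo sapiens) (on this read-out higher numbers stand for weaker inhibition and lower numbers for stronger inhibition), compound 1 `O[C@H]1Cc2ccccc2C1NC1CCN(CCCc2c[nH]c3ccc(-n4cnnc4)cc23)CC1` gives 37 nM, compound 2 `CN(C1CCN(CCCc2c[nH]c3ccc(-n4cnnc4)cc23)CC1)S(=O)(=O)c1ccccc1` gives 1.5 nM, and compound 3 `c1cc(CNC2CCN(CCCc3c[nH]c4ccc(-n5cnnc5)cc34)CC2)co1` gives 4.5 nM. Compound 3 thus stands second highest of the three numbers, with a 3.0-fold higher number from compound 2 to compound 3 (0.48 log units; beyond the scatter) and an 8.2-fold lower number from compound 1 to compound 3 (0.91 log units; beyond the scatter). Compound 4 `c1ccc(NCC2CCN(CCCc3c[nH]c4ccc(-n5cnnc5)cc34)CC2)nc1` differs from compound 3 by ((pyridin-2-yl)amino)methyl in place of ((furan-3-yl)methyl)amino on a saturated ring carbon. The measured steps of a 25-fold lower number from compound 1 to compound 2 (1.39 log units; beyond the scatter), an 8.2-fold lower number from compound 1 to compound 3 (0.91 log units; beyond the scatter) and a 3.0-fold higher number from compound 2 to compound 3 (0.48 log units; beyond the scatter) all concern this same place and range from modest to large. None of them involves the entering group, so a modest step in either direction is expected. Compound 4 is therefore estimated at 5 nM, between 1.5 nM and 15 nM. That estimate is expected to mean a 1.1-fold higher number from compound 3 to compound 4 (0.05 log units; within the scatter).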

Compound 4, half-maximal inhibitory concentration: 1.7 nM
Beside the measured number, compound 4's estimate is 2.9-fold (0.47 log units) above it; low and high end bracket the measured number.
By their numbers in this assay, from the lowest: compounds 2 and 4 (each within the scatter of the next); then compound 3; then compound 1.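

Within the data shown here, on this saturated ring carbon, ((pyridin-2-yl)amino)methyl is the first group attached through carbon rather than nitrogen, and a 2.6-fold lower number from compound 3 to compound 4 (0.42 log units; beyond the scatter) shows that this attachment is accepted. With a 1.1-fold higher number from compound 2 to compound 4 (0.05 log units; within the scatter) it stands level with methyl(phenylsulfonyl)amino, while a 22-fold lower number from compound 1 to compound 4 (1.34 log units; beyond the scatter) leaves (2-hydroxy-2,3-dihydro-1H-inden-1-yl)amino alone at the high end. No evidence at hand accounts for these steps. The compounds shown leave open whether the pyridine ring nitrogen matters, which a phenyl ring in its place would test, and how a carboxylic acid or a longer chain on this carbon would read.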